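A few compounds are considered here, and "the series" means these few. Any claim that something is new, unique, unknown or untested is made for them only; others in the source may bear on it.

Measured in a functional assay on MDA-MB-435 cells (Homo sapiens) for inhibition; on this read-out higher numbers stand for weaker inhibition and lower numbers for stronger inhibition:
- Compound 1 `COc1cc[nH]c1/C=C1\C(=O)Nc2ccc(F)c(I)c21`: > 30000 nM, a limit of the assay and not a number
- Compound 2 `COc1cc[nH]c1/C=C1\C(=O)Nc2ccc(F)c(C#C[C@H](C)O)c21`: 190 nM
- Compound 3 `COc1cc[nH]c1/C=C1\C(=O)Nc2ccc(F)c(C#CC(O)CN)c21`: 130 nM

Compound 3 shares its place on the numbers with compound 2, and the gap between them lies within the scatter: a 1.5-fold lower number from compound 2 to compound 3 (0.16 log units; within the scatter). Compound 1 offers no number for comparison, only its limit.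

Compound 4 `COc1cc[nH]c1/C=C1\C(=O)Nc2ccc(F)c(C#C[C@H](N)CO)c21` has the same atoms as compound 3, joined differently: 1-amino-2-hydroxyethyl in place of 2-amino-1-hydroxyethyl on a triple-bonded carbon. The 4-amino-3-hydroxybut-1-yn-1-yl group gives way to 3-amino-4-hydroxybut-1-yn-1-yl, so the amino and hydroxyl groups trade places on the chain, and the new group carries one defined stereocentre.

Two large steps came from replacing iodo with such a chain: an at least 150-fold lower number from compound 1 to compound 2 (2.19 log units; beyond the scatter) and an at least 230-fold lower number from compound 1 to compound 3 (2.36 log units; beyond the scatter). Compound 4 keeps a chain of this kind, so those gains should largely remain. The closest measured change, in the group on the triple-bonded carbon, is a 1.5-fold lower number from compound 2 to compound 3 (0.16 log units; within the scatter), which is within the scatter. For the measured compounds named here, no measured pair moves the amino group itself, so the range must stay wide.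

No change beyond the scatter is expected, and the estimated step is a 1.2-fold higher number from compound 3 to compound 4 (0.06 log units; within the scatter). For compound 4 the expected value in this assay is 150 nM, with an estimated range of 40 nM to 600 nM.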

Compound 4, half-maximal inhibitory concentration: 320 nM
Compound 4: the middle estimate sits 2.1-fold (0.33 log units) below what was measured; low and high end bracket the measured number.
By their numbers in this assay, from the lowest: compounds 3, 2 and 4 (each within the scatter of the next, the first and the last beyond it). At a limit, above all of these: compound 1.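

Swapping the amino and hydroxyl groups along the chain, from 4-amino-3-hydroxybut-1-yn-1-yl to 3-amino-4-hydroxybut-1-yn-1-yl, is the first change among these chains on the triple-bonded carbon to go beyond the scatter in this assay: a 2.5-fold higher number from compound 3 to compound 4 (0.39 log units; beyond the scatter). This modest step shows that the arrangement of the groups can register at this position even when the atoms and the counts of hydrogen-bond donors and acceptors stay the same, while the comparison with the chain that has no amino group stays within the scatter, with a 1.7-fold higher number from compound 2 to compound 4 (0.23 log units; within the scatter). The large gain over iodo also holds for this further chain, with an at least 93-fold lower number from compound 1 to compound 4 (1.97 log units; beyond the scatter), but its size is only a bound: the limit of > 30000 nM in this assay, at which 1 of the 4 values shown sits.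

The compounds shown leave open whether the opposite configuration at the defined stereocentre of compound 4 would read differently, so the part played by that stereocentre in the step from the 4-amino-3-hydroxybut-1-yn-1-yl chain cannot be separated from the swap itself. They also leave open how a dimethylamino group in place of the amino group, or a longer chain carrying the same two groups, would fare at this position.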